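Exchanging a Ring Acid for an Amide

The source may report more compounds than this note shows. Statements on the series, on what has been measured and on what is new or still open speak of the compounds shown alone.

Measured compounds:
compound 1 `CC[C@]1(C(=O)O)CC[C@H](C(=O)N2CC[C@](c3ccc(C(F)(C(F)(F)F)C(F)(F)F)cc3)(S(=O)(=O)c3ccc(F)cc3)C2)CC1` — 100%
compound 2 `O=C(N1CC[C@](c2ccc(C(F)(C(F)(F)F)C(F)(F)F)cc2)(S(=O)(=O)c2ccc(F)cc2)C1)C12CCC(C(=O)O)(CC1)OC2` — "not determined" (no result reported)

Compound 1 holds the only number shown. In an ADME assay on microsomes from liver (Homo sapiens) for metabolic stability, with a stated time of 10 min (a higher number here means that more of the compound is left, a lower number that less of the compound is left), compound 1 gives 100%, the full amount remaining. For compound 2 this assay shows "not determined" (no result reported). Compound 3 `NC(=O)[C@H]1CC[C@H](C(=O)N2CC[C@](c3ccc(C(F)(C(F)(F)F)C(F)(F)F)cc3)(S(=O)(=O)c3ccc(F)cc3)C2)CC1` differs from compound 1 in one place: 4-carbamoylcyclohexyl in place of 4-carboxy-4-ethylcyclohexyl on a carbonyl carbon. Among the measured compounds shown here, no step between two measured compounds is available, so the size of this change can only be guessed. A modest drop is expected, a number 15 percentage points lower from compound 1 to compound 3 (beyond the scatter), reaching beyond the usual scatter only at its lower end. Compound 3 is therefore estimated at 85%, within a range from 60% to 100%.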

Compound 3, percent of the compound remaining: 100%
The estimate for compound 3 lay 15 percentage points below the measured number; low and high end bracket the measured number.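

In this assay, the exchange on this carbonyl carbon gives no change at the digits printed from compound 1 to compound 3 (within the scatter), so the amide-bearing ring serves here as well as the ring with the acid and ethyl group. Compound 3 gives 100%, the full amount remaining, which means that a carboxylic acid on this ring is not required for that reading. No measurement at hand explains this result. Because the acid and the ethyl group leave together, their separate contributions stay unresolved. A 4-carboxycyclohexyl group, or an amine on this ring, would remain to be compared.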